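Benzyl ester of compound 1: expected tail flick read-out

The source may hold more compounds than are shown below. What is called first, only, known or untested is meant among the compounds shown, and "the series" means these compounds.

Of the compounds shown here, two carry numbers so far. Compound 1 `O=C(O)[C@@H]1CCCN1C(=O)CN(c1nc(Cl)nc2[nH]cnc12)C1CC1` in a functional assay on the whole organism (Tail, strain ICR) with Mus musculus as the target, in the tail flick test, with a stated time of 120 min, at a dose of 25 umol/kg by the oral route (on this read-out higher numbers stand for a stronger effect at the one dose given and lower numbers for a weaker effect), gives 23.6%. Compound 2 `O=C(CN(c1ncnc2c1ncn2C1CCCCO1)C1CC1)NCC(=O)OCc1ccccc1` in this assay gives 17.2%. Among the compounds with values here, on these two numbers compound 1 stands nominally higher, but compound 2 lies within the scatter of it, so the two are not separated, and no step between measured compounds is available.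

Compound 3 `O=C(OCc1ccccc1)[C@@H]1CCCN1C(=O)CN(c1nc(Cl)nc2[nH]cnc12)C1CC1` is not yet measured. It differs from compound 1 by benzyl in place of hydrogen on an oxygen next to a carbonyl group, benzyl entering on an oxygen next to a carbonyl group whose other neighbour is the carbonyl carbon.

Within the data shown here, with no measured step to lean on and compound 2, itself a benzyl ester, giving 17.2%, the expected step of a number 2.6 percentage points lower from compound 1 to compound 3 (within the scatter) is small and within the scatter. For compound 3 the estimated read-out in this assay is 21%, with a range from 8% to 36%.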

Compound 3, a percentage reported as activity, at one dose (the size of the read-out at that dose, not a potency): 38.4%
The estimate for compound 3 lay 17.4 percentage points below the measured number; measured number outside the range, above it.
By their numbers in this assay, from the lowest: compounds 2 and 1 (each within the scatter of the next); then compound 3.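

Within the data shown here, putting benzyl in place of hydrogen on the oxygen next to the carbonyl group, carboxy to benzyloxycarbonyl, gives a number 14.8 percentage points higher from compound 1 to compound 3 (beyond the scatter) in this assay, the only step available so far and one that clears the scatter. This position is therefore not silent, and the free carboxy group is not needed for the read-out at the one dose given. Nothing measured here accounts for the step.

As far as these compounds go, whether the gain belongs to benzyl itself or to esters in general remains open; a methyl ester, an ethyl ester or a primary amide at this position would separate those readings. Among these compounds, also open is whether the step holds at another dose or time, as the series so far has one dose and one time.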